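A few compounds are considered here, and "the series" means these few. Any claim that something is new, unique, unknown or untested is made for them only; others in the source may bear on it.

In a functional assay on KB cells (Homo sapiens) for inhibition, read by sulforhodamine B assay, with a stated time of 72 h (a lower number here means a stronger inhibitor of growth, a higher number a weaker inhibitor of growth), compound 1 `CCOC(=O)/C=C/c1ccncc1-c1ccc2ccccc2c1` gives > 10000 nM, which is a limit. Compound 2 `O=C(/C=C/c1ccncc1-c1ccc2ccccc2c1)N1CCOCC1` gives > 10000 nM, also a limit, so it stands without a readable number. The record so far comes down to the limit of > 10000 nM in this assay, at which 2 of the 2 values shown sit. Compound 3 `CN(C)C(=O)/C=C/c1ccncc1-c1ccc2ccccc2c1` differs from compound 2 in one place: dimethylamino in place of morpholin-4-yl on a carbonyl carbon. Among the measured compounds shown here, the only measured step is a step that the two limits leave unreadable from compound 1 to compound 2, on the same carbonyl carbon. It gives no size to carry over, so no step beyond the scatter is expected in this assay, in either direction. The expected result is a step that the limit leaves unreadable from compound 2 to compound 3. For compound 3 the estimate is 15000 nM, within an expected range of 6000 nM to 40000 nM.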

Compound 3, concentration for 50% growth inhibition: 7760 nM
Estimate against measurement, compound 3: 1.9-fold (0.29 log units) above; low and high end bracket the measured number.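

In this assay, among the compounds shown here, compound 3 is the only one of the three compounds with a readable number, so dimethylamino on the carbonyl carbon is the first group here to give a value rather than a limit: the limit of > 10000 nM in this assay, at which 2 of the 3 values shown sit. Dimethylamino in place of morpholin-4-yl gives an at least 1.2-fold lower number from compound 2 to compound 3 (0.11 log units; that floor lies within the scatter), and dimethylamino in place of ethoxy gives an at least 1.2-fold lower number from compound 1 to compound 3 (0.11 log units; that floor lies within the scatter). Both steps are floors, so the true gaps could be larger, but neither is shown to lie beyond the scatter. The compounds shown leave open how diethylamino, pyrrolidin-1-yl or a carboxylic acid would read on this carbonyl carbon.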